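The compounds below may be only part of what the source reports. "The series", "measured", "known", "first", "only" and "open" are said of these compounds alone.

Compound 1, `Cc1ccc(NC(=O)N[C@H]2CC[C@H](Oc3ccc(F)cc3)CC2)cc1`: in a functional assay on CRL2813 cells (Homo sapiens) for cytotoxicity, read by sulforhodamine B assay, with a stated time of 5 days (a higher number here means a weaker inhibitor, a lower number a stronger inhibitor), compound 1 gives > 20000 nM, which is a limit of the assay and not a number.
Compound 2, `O=C(Nc1ccc(Cl)cc1)N[C@H]1CC[C@H](Oc2ccc(F)cc2)CC1`: in this assay compound 2 gives > 20000 nM, again only a limit.
Compound 3, `O=C(Nc1ccccc1I)N[C@H]1CC[C@H](Oc2ccc(F)cc2)CC1`: in this assay compound 3 gives > 20000 nM, again only a limit.

The three compounds share one core and differ only in the aryl group carried on the amide-type nitrogen. Compound 3 therefore stands nowhere in particular on the numbers shown: its value is a limit, and the two other values are limits as well (the limit of > 20000 nM in this assay, at which 3 of the 3 values shown sit). The steps between the measured compounds are accordingly all unreadable: a step that the two limits leave unreadable from compound 1 to compound 2, a step that the two limits leave unreadable from compound 1 to compound 3 and a step that the two limits leave unreadable from compound 2 to compound 3.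

Compound 4, `O=C(Nc1cccc(Br)c1)N[C@H]1CC[C@H](Oc2ccc(F)cc2)CC1`, differs from compound 3 by 3-bromophenyl in place of 2-iodophenyl on an amide-type nitrogen. Going by the values given here, none of the measured steps can give a size or a direction for this change, since each of them runs between two limits. What the data do show is that every aryl group tried so far leaves the compound at the limit (the limit of > 20000 nM in this assay, at which 3 of the 3 values shown sit), and compound 4 is expected to do the same. The step that the limit leaves unreadable from compound 3 to compound 4 is thus expected to be none beyond the scatter. For compound 4 the estimate in this assay is 30000 nM, with a range from 15000 nM to 80000 nM.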

Compound 4, half-maximal inhibitory concentration: 6200 nM
The estimate for compound 4 lay 4.8-fold (0.68 log units) above the measured number, and the stated range ends above it.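

On the amide-type nitrogen, the choice of aryl group can make a readable difference in this assay: 3-bromophenyl in place of 2-iodophenyl gives an at least 3.2-fold lower number from compound 3 to compound 4 (0.50 log units; beyond the scatter), 3-bromophenyl in place of 4-chlorophenyl gives an at least 3.2-fold lower number from compound 2 to compound 4 (0.50 log units; beyond the scatter), and 3-bromophenyl in place of 4-methylphenyl gives an at least 3.2-fold lower number from compound 1 to compound 4 (0.50 log units; beyond the scatter). Each of these sizes is only a lower bound, so the true gaps may be larger, while the steps among compound 1, compound 2 and compound 3 still cannot be read. Compound 4 is the only one of the four compounds with a measured number in this series, and the other three remain at a limit of the assay: the limit of > 20000 nM in this assay, at which 3 of the 4 values shown sit.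

Going by these compounds, whether the change comes from the bromine itself or from where it sits on the phenyl ring stays open: compound 4 differs from each of compound 1, compound 2 and compound 3 in both the substituent and its place. Also open, on these data alone, is how this assay would respond to an amine or a carboxylic acid on that phenyl ring, or to a nitrile in place of the bromine.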